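A cyclohexylcarbamoyl swap on compound 1

A few compounds are considered here, and "the series" means these few. Any claim that something is new, unique, unknown or untested is made for them only; others in the source may bear on it.

Compound 1 `Cc1ccccc1NC(=O)Nc1ccc(Nc2ncnc3c2cnn3-c2ccc(Cl)cc2)cc1` reads 3150 nM
Compound 2 `O=c1sc2cc(Nc3ncnc4c3cnn4-c3ccc(Cl)cc3)ccc2n1Cc1ccc(Cl)cc1Cl` reads > 100000 nM (a limit of the assay)

Among the measured compounds shown here, in a functional assay on MCF7 cells (Homo sapiens) for cytotoxicity, read by sulforhodamine B assay, with a stated time of 72 h (on this read-out lower numbers stand for stronger inhibition and higher numbers for weaker inhibition), compound 1 at 3150 nM holds the only true number so far. Compound 2 at > 100000 nM in this assay is only a limit of the assay and not a number. For the measured compounds named here, that leaves compound 1 as the single firm reference point, with no measured step to set a scale.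

Compound 3 `O=C(NC1CCCCC1)c1ccc(Nc2ncnc3c2cnn3-c2ccc(Cl)cc2)cc1` keeps the core of compound 1 but carries cyclohexylcarbamoyl in place of ((2-methylphenyl)carbamoyl)amino on an aromatic carbon (para to a large group). The exchange cyclohexylcarbamoyl in place of ((2-methylphenyl)carbamoyl)amino on an aromatic carbon is the only difference between the two.

Going by the values given here, no measured pair shows what such an exchange does in this assay so the expectation rests on compound 1 at 3150 nM and on the change itself. A moderate loss is expected rather than a large one, with the estimated change a 2.5-fold higher number from compound 1 to compound 3 (0.40 log units; beyond the scatter) pointing toward weaker inhibition. In this assay compound 3 is expected at 8000 nM with an estimated range from 1500 nM to 40000 nM as the span for this measurement.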

Compound 3, half-maximal inhibitory concentration: > 100000 nM
Compound 3 ended at the assay's limit; the forecaster's own chance of this, stated with the estimate: 15%; middle value at least 12-fold (1.09 log units) from the limit.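

In this assay, among the compounds shown here, the place para to a large group proves far from indifferent to this exchange: cyclohexylcarbamoyl in place of ((2-methylphenyl)carbamoyl)amino gives an at least 31-fold higher number from compound 1 to compound 3 (1.50 log units; beyond the scatter), the first measured step and one that counts as large. The value of compound 3, > 100000 nM, is a limit of the assay and not a number. The step therefore sets only a lower bound on the change, and compound 1 remains the only compound with a true number, as the same limit recurs among the compounds shown: the limit of > 100000 nM in this assay, at which 2 of the 3 values shown sit.

The exchange replaces an aromatic ring with a non-aromatic one and alters the linking atoms and the hydrogen-bond donors all at once, and the compounds shown do not separate these changes, so which of them goes with the loss stays open. Also open, on these data alone, is whether a phenylcarbamoyl group, an amine or a carboxylic acid on this aromatic carbon would return a true number in this assay or end at the same limit.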